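This account rests on a few compounds, and the source may have more. Where it says the series, first, only, none or still open, it means among the compounds named here.

Values in a functional assay on CCRF-CEM cells (Homo sapiens) for inhibition, read by MTT assay, with a stated time of 72 h; a higher number here means a weaker inhibitor, a lower number a stronger inhibitor:
- compound 1 `COc1cc(NC(C)CCCNC(=O)Nc2cccc(F)c2)c2ncccc2c1`: 21000 nM
- compound 2 `COc1cc(NC(C)CCCNC(=O)Nc2ccc(F)cc2)c2ncccc2c1`: 26000 nM
- compound 3 `COc1cc(NC(C)CCCNC(=O)NNC(=O)Nc2cccc(C(F)(F)F)c2)c2ncccc2c1`: 6900 nM

Compound 2, at 26000 nM, lies within the usual scatter of compound 1, so these two cannot be ranked. Compound 3, at 6900 nM, has a clearly lower number than both, which marks it as the stronger inhibitor in this assay. However, no single-place change connects compound 3 to the others, so it gives little direct guidance here.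

The next compound is compound 4 `COc1cc(NC(C)CCCNC(=O)Nc2ccc(Cl)cc2)c2ncccc2c1`, which differs from compound 2 by chloro in place of fluoro on an aromatic carbon. For the measured compounds named here, the one measured step that bears on this is a 1.2-fold higher number from compound 1 to compound 2 (0.09 log units; within the scatter), with 4-fluorophenyl in place of 3-fluorophenyl. Going by the values given here, no measured pair puts chloro in place of fluoro, so this evidence is only indirect, and no clear direction can be drawn from it.

The expected step is a 1.3-fold lower number from compound 2 to compound 4 (0.11 log units; within the scatter), which would not stand out from the scatter. For compound 4 the estimated value is 20000 nM, with an expected range from 10000 nM to 40000 nM.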

Compound 4, half-maximal inhibitory concentration: 24000 nM
Estimate against measurement, compound 4: 1.2-fold (0.08 log units) below, within the range that was stated.
By their numbers in this assay, from the lowest: compound 3; then compounds 1, 4 and 2 (each within the scatter of the next).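

In this assay, chloro in place of fluoro on an aromatic carbon para to a large group gives a 1.1-fold lower number from compound 2 to compound 4 (0.03 log units; within the scatter) and stays within the scatter, so these two halogens cannot be told apart at this position. Moving to the 4-chlorophenyl from the 3-fluorophenyl gives a 1.1-fold higher number from compound 1 to compound 4 (0.06 log units; within the scatter) and also stays within the scatter, so compounds 1, 2 and 4 form a flat group in which neither change shifts the number measurably. Nothing available here explains this flat result.

As far as these compounds go, it remains open whether a different kind of group at this position, such as an amine or a carboxylic acid, would shift the number beyond the scatter. Also open, from the compounds shown here alone, is which part of compound 3 goes with its lower number, since it differs from the others in more than one place.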